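Pyrazole amide at the carbonyl of the dioxin-fused thiophene series

The compounds below may be only part of what the source reports. "The series", "measured", "known", "first", "only" and "open" are said of these compounds alone.

Measured so far:
- Compound 1 `O=C(NCc1ccc(CNS(=O)(=O)c2ccc3c(c2)CCO3)cc1)c1cccc2c1COC2`; in an assay on cells for inhibition of C-X-C chemokine receptor type 4 (Homo sapiens), with a stated time of 22 h, tested at 100 nM (on this read-out higher numbers stand for more inhibition at the one concentration tested (going by the name of the read-out) and lower numbers for less inhibition), compound 1 gives 40%.
- Compound 2 `O=C(NCc1ccc(CNS(=O)(=O)c2ccc3c(c2)CCO3)cc1)c1scc2c1OCCO2`; in this assay compound 2 gives 68%.

Compound 2 holds the higher of the two numbers, and its gap to compound 1 is beyond the scatter: a number 28 percentage points higher from compound 1 to compound 2 (beyond the scatter). Compound 3 `Cc1cc(C(=O)NCc2ccc(CNS(=O)(=O)c3ccc4c(c3)CCO4)cc2)n(C)n1` is drawn from compound 2 by the change (a group of 7 heavy atoms (5 carbon, 2 nitrogen; one five-membered aromatic ring with 2 hetero atoms) in place of a group of 9 heavy atoms (6 carbon, 2 oxygen, 1 sulfur; one five-membered aromatic ring with 1 hetero atom, one six-membered non-aromatic ring with 2 hetero atoms), on a carbonyl carbon).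

Among the compounds with values here, only one measured step touches this position, the one from compound 1 to compound 2, and it shows that the group on the carbonyl carbon can move the read-out by a modest amount. Within the data shown here, the group entering in compound 3 resembles neither of the two already tested, so no direct precedent exists; the step is expected to be a number 23 percentage points lower from compound 2 to compound 3 (beyond the scatter), downward, since a swap at this place has already shifted the number beyond the scatter and the higher value of compound 2 leaves more room to fall than to climb. Compound 3 is therefore estimated at 45%, with a range from 20% to 70%.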

Compound 3, a percentage reported as inhibition, at one concentration (the size of the read-out at that concentration, not a potency): "active" (no number reported)
For compound 3 the study gives words and no number; no gap can be computed for the estimate.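

Within the data shown here, compound 3 is reported only as active, without a number, so no step from compound 2 to compound 3 can be read. No further data bear on this result. The compounds shown leave open how the 1,3-dimethyl-1H-pyrazol-5-yl group ranks against the groups of compound 1 and compound 2.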